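Swapping phenyl for tert-butyl at the assay limit

A few compounds are considered here, and "the series" means these few. Any claim that something is new, unique, unknown or untested is made for them only; others in the source may bear on it.

- compound 1 `Cc1ccc(-c2cc(/N=C3/NC(=O)CS3)cs2)cc1`: > 50000 nM (a limit)
- compound 2 `O=C1CS/C(=N\c2csc(-c3ccccc3)c2)N1`: > 50000 nM (a limit)
- compound 3 `O=C1CS/C(=N\c2csc(-c3ccc(Cl)cc3)c2)N1`: > 50000 nM (a limit)

These three compounds were tested in a functional assay on MDA-MB-231 cells (Homo sapiens) for cytotoxicity, read by MTT assay, with a stated time of 72 h; on this read-out lower numbers stand for stronger inhibition and higher numbers for weaker inhibition. Compound 2 has no exact number, only a limit: > 50000 nM. The other two compounds are also limits, so compound 2 cannot be placed in an order with them. The whole set comes down to the limit of > 50000 nM in this assay, at which 3 of the 3 values shown sit.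

Compound 4 `CC(C)(C)c1cc(/N=C2/NC(=O)CS2)cs1` has not yet been measured. Its change from compound 2 is tert-butyl in place of phenyl on an aromatic carbon. In words, this is tert-butyl in place of phenyl on an aromatic carbon, next to the ring sulfur.

Three measured steps alter a group on the phenyl that leaves here: a step that the two limits leave unreadable from compound 1 to compound 2, a step that the two limits leave unreadable from compound 1 to compound 3 and a step that the two limits leave unreadable from compound 2 to compound 3. None of them has a readable size, and none removes the phenyl itself, so they give no size or direction to carry over. Going by the values given here, the only guide is the limit of > 50000 nM in this assay, at which 3 of the 3 values shown sit, and on that basis no step beyond the scatter is expected in this assay, though this expectation is weak.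

The expected change is a number no higher from compound 2 to compound 4 (the limit leaves the size open).

For compound 4 the estimated value is 50000 nM, with an expected range from 20000 nM to 100000 nM.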

Compound 4, half-maximal inhibitory concentration: > 50000 nM
Compound 4: only a limit was reported; the forecaster's own chance of this, stated with the estimate: 80%; the middle value lies on the limit itself.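

In this assay compound 4 gives > 50000 nM, which is a limit. Going by these compounds alone, compound 2 also has only a limit, so no step between compound 2 and compound 4 can be read, and the effect of tert-butyl in place of phenyl has no readable size. The compounds shown leave open how they rank against one another, since all stop at the same point: the limit of > 50000 nM in this assay, at which 4 of the 4 values shown sit.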